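The compounds below may be only part of what the source reports. "The series", "measured", "known", "first", "only" and "open" are said of these compounds alone.

Measured compounds:
compound 1 `COc1ccc2c(c1)C(n1ccccc1=O)=CC(C)(C)O2` — 6.55
compound 2 `CCC(=O)c1ccc2c(c1)C(n1ccccc1=O)=CC(C)(C)O2` — 6.63
compound 3 `CC1(C)C=C(n2ccccc2=O)c2cc(C(=O)c3ccco3)ccc2O1` — 6.49

All three were tested in a functional assay (aorta) with Rattus norvegicus as the target (on this read-out lower numbers stand for lower potency and higher numbers for higher potency (the scale is a negative logarithm)), and compound 3 is the point of departure. Its value sits within the scatter of both neighbours: the change a number 0.06 log units lower from compound 1 to compound 3 (within the scatter) and the change a number 0.14 log units lower from compound 2 to compound 3 (within the scatter) are both too small to count as real differences, so the three compounds cannot be ranked against each other on this read-out.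

Compound 4 `CC1(C)C=C(n2ccccc2=O)c2cc(C(=O)c3ccccc3F)ccc2O1` is the next compound and has not yet been measured. It differs from compound 3 at a single place: 2-fluorophenyl in place of furan-2-yl on a carbonyl carbon.

Going by the values given here, the only measured step that touches the same place is the change a number 0.14 log units lower from compound 2 to compound 3 (within the scatter), where furan-2-yl replaced ethyl on the carbonyl carbon without moving the number beyond the scatter. The change at the aromatic carbon, a number 0.08 log units higher from compound 1 to compound 2 (within the scatter), points the same way: the shared core appears to carry the potency and the group on the carbonyl carbon has so far hardly mattered. Compound 4 is therefore expected to show a step of a number 0.06 log units higher from compound 3 to compound 4 (within the scatter) in this assay, that is none beyond the scatter. The estimate for compound 4 is 6.55, expected to lie between 6.1 and 7.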

Compound 4, logarithm of the reciprocal of the active concentration, log(1/C): 7.08
Beside the measured number, compound 4's estimate is 0.53 log units below it; measured number above the stated range.
By their numbers in this assay, from the lowest: compounds 3, 1 and 2 (each within the scatter of the next); then compound 4.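

In this assay, going by these compounds alone, the group on the carbonyl carbon turns out to matter: 2-fluorophenyl gives a number 0.59 log units higher from compound 3 to compound 4 (beyond the scatter) against furan-2-yl and a number 0.45 log units higher from compound 2 to compound 4 (beyond the scatter) against ethyl, the first steps at this place to clear the scatter, whereas furan-2-yl and ethyl could not be told apart. Against methoxy on the aromatic carbon, the whole (2-fluorophenyl)carbonyl group gives a number 0.53 log units higher from compound 1 to compound 4 (beyond the scatter) and so compound 4 stands clear of all three earlier compounds, though each step is only modest. No measurement at hand accounts for this gain.

The compounds shown leave open whether the step belongs to the fluorine or to the six-membered aromatic ring itself, a question that plain phenyl on the carbonyl carbon would address. Also open, on these data alone, is how 2-chlorophenyl would compare at this place.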